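A few compounds are considered here, and "the series" means these few. Any claim that something is new, unique, unknown or untested is made for them only; others in the source may bear on it.

Three compounds share the core of compound 3 `CCNC(=O)[C@H]1O[C@@H](n2cnc3c(NNC(=O)c4ccc[nH]4)nc(Cl)nc32)[C@H](O)[C@@H]1O` and differ only in the aromatic ring attached to the carbonyl carbon. In an assay on CHO cells for displacement of a labelled ligand from adenosine receptor A3 (Homo sapiens) (a higher number here means a weaker inhibitor, a lower number a stronger inhibitor), compound 3 gives > 5000 nM, which is a limit of the assay rather than a number. Compound 1 `CCNC(=O)[C@H]1O[C@@H](n2cnc3c(NNC(=O)c4ccco4)nc(Cl)nc32)[C@H](O)[C@@H]1O` gives > 5000 nM in this assay, again a limit. Compound 2 `CCNC(=O)[C@H]1O[C@@H](n2cnc3c(NNC(=O)c4cccs4)nc(Cl)nc32)[C@H](O)[C@@H]1O` gives > 5000 nM in this assay, likewise a limit. Because (the limit of > 5000 nM in this assay, at which 3 of the 3 values shown sit), none of the steps between them can be read: a step that the two limits leave unreadable from compound 1 to compound 2, a step that the two limits leave unreadable from compound 1 to compound 3 and a step that the two limits leave unreadable from compound 2 to compound 3 all remain of unknown size. Compound 3 therefore stands level with the other two, at the limit. Compound 4 `CCNC(=O)[C@H]1O[C@@H](n2cnc3c(NNC(=O)c4cc(C)on4)nc(Cl)nc32)[C@H](O)[C@@H]1O` brings the change (5-methyl-1,2-oxazol-3-yl in place of 1H-pyrrol-2-yl on a carbonyl carbon). Among the measured compounds shown here, no measured step bears on this exchange, and the three limits give no direction. Compound 4 is expected to sit near or beyond the same limit, with the step that the limit leaves unreadable from compound 3 to compound 4 of no readable size. Compound 4 is estimated at 10000 nM in this assay, within the range from 3000 nM to 50000 nM.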

Compound 4, inhibition constant: > 5000 nM
Compound 4: a limit, no number (the forecaster's own chance of this, stated with the estimate: 80%); the middle value does not contradict the limit.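

Compound 4 gives > 5000 nM in this assay, again a limit and not a number, so no step between compound 4 and compound 1, compound 2 or compound 3 can be read: the limit of > 5000 nM in this assay, at which 4 of the 4 values shown sit.

The compounds shown leave open whether the aromatic ring on the carbonyl carbon affects the inhibition constant at all.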